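Adding One Methoxy Group to Compound 2

This account rests on a few compounds, and the source may have more. Where it says the series, first, only, none or still open, it means among the compounds named here.

- compound 1 `COc1cccc(/C=C/C(=O)C(=Cc2ccc(F)cc2)C(=O)/C=C/c2cccc(OC)c2OC)c1OC` gives 340 nM
- compound 2 `COc1ccc(C=C(C(=O)/C=C/c2cccc(OC)c2OC)C(=O)/C=C/c2cccc(OC)c2OC)cc1OC` gives 170 nM
- compound 3 `COc1cc(C=C(C(=O)/C=C/c2cccc(OC)c2OC)C(=O)/C=C/c2cccc(OC)c2OC)cc(OC)c1O` gives 240 nM

In a functional assay on A549 cells (Homo sapiens) for antiproliferative activity, read by sulforhodamine B assay, with a stated time of 48 h (on this read-out lower numbers stand for stronger inhibition and higher numbers for weaker inhibition), compound 2, at 170 nM, cannot be told apart from compound 1 or compound 3: all three values lie within the usual scatter of one another. Compound 4 `COc1cccc(/C=C/C(=O)C(=Cc2ccc(OC)c(OC)c2OC)C(=O)/C=C/c2cccc(OC)c2OC)c1OC` differs from compound 2 by methoxy in place of hydrogen on an aromatic carbon, which turns 3,4-dimethoxyphenyl into 2,3,4-trimethoxyphenyl. Three measured exchanges at this same group bear on it: a 2.0-fold lower number from compound 1 to compound 2 (0.30 log units; within the scatter), a 1.4-fold lower number from compound 1 to compound 3 (0.15 log units; within the scatter) and a 1.4-fold higher number from compound 2 to compound 3 (0.15 log units; within the scatter), all within the scatter. No step beyond the scatter is therefore expected in this assay, in either direction. The estimated change is only a 1.2-fold higher number from compound 2 to compound 4 (0.07 log units; within the scatter). Compound 4 is expected at 200 nM, with an estimated range of 80 nM to 500 nM.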

Compound 4, half-maximal inhibitory concentration: 260 nM
Compound 4: middle estimate off by 1.3-fold (0.11 log units), on the low side, within the range that was stated.
By their numbers in this assay, from the lowest: compounds 2, 3, 4 and 1 (each within the scatter of the next).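

In this assay, methoxy in place of hydrogen on this aromatic carbon, ortho to a large group, gives a small step (a 1.5-fold higher number from compound 2 to compound 4 (0.18 log units; within the scatter)), so the added group brings no change beyond the scatter. The two exchanges of the whole aromatic group read the same way (a 1.1-fold higher number from compound 3 to compound 4 (0.03 log units; within the scatter); a 1.3-fold lower number from compound 1 to compound 4 (0.12 log units; within the scatter)). No measurement shown offers an explanation for these steps.

Still open, as far as these compounds go, is whether a different group at this position, such as an amine or a carboxylic acid, would give a step beyond the scatter.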